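A Chloro Group Next to the Ring Nitrogen

A few compounds are considered here, and "the series" means these few. Any claim that something is new, unique, unknown or untested is made for them only; others in the source may bear on it.

Compound 1 `O=S(=O)(/C=C/c1ccccn1)c1ccc(F)cc1` is the starting point. For the measured compounds named here, in an assay on U2OS cells for activation of nuclear factor erythroid 2-related factor 2 (Homo sapiens), read by beta-arrestin recruitment, with a stated time of 6 h (on this read-out lower numbers stand for an effect already at smaller amounts and higher numbers for an effect only at larger amounts of compound), compound 1 gives 3100 nM, the highest of the two numbers measured so far. Compound 2 `O=S(=O)(/C=C/c1ncccc1Cl)c1ccc(F)cc1` gives 231 nM, and the step of a 13-fold lower number from compound 1 to compound 2 (1.13 log units; beyond the scatter) came from a chloro in place of hydrogen on an aromatic carbon. Compound 3 `O=S(=O)(/C=C/c1cccc(Cl)n1)c1ccc(F)cc1` carries that same kind of change at another spot: chloro in place of hydrogen on an aromatic carbon, next to the ring nitrogen. Only the large step to compound 2 bears on it, and the position differs, so a smaller drop is expected, a 2.6-fold lower number from compound 1 to compound 3 (0.41 log units; beyond the scatter). Compound 3 is therefore estimated at 1200 nM, within 300 nM to 4000 nM.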

Compound 3, half-maximal effective concentration: 2790 nM
Compound 3: the middle estimate sits 2.3-fold (0.37 log units) below what was measured; the range from low to high includes it.
By their numbers in this assay, from the lowest: compound 2; then compounds 3 and 1 (each within the scatter of the next).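

Next to the ring nitrogen, chloro in place of hydrogen leaves the number in this assay within the scatter, with a 1.1-fold lower number from compound 1 to compound 3 (0.05 log units; within the scatter) set against a 13-fold lower number from compound 1 to compound 2 (1.13 log units; beyond the scatter) for chloro at the other spot. Among these compounds, then, the same swap gives a clear drop at only one place on this ring, so its position matters here. No measurement given here explains this difference between the two spots. Still open, going by these compounds, is whether a methoxy group or an amine next to the ring nitrogen would shift the number, and whether fluoro or methyl at the chloro spot of compound 2 would match chloro.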